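Removing a Nitrile from Two Related Cores

A few compounds are considered here, and "the series" means these few. Any claim that something is new, unique, unknown or untested is made for them only; others in the source may bear on it.

Compound 1 `Cc1cc(Cl)nc2c1c(C#N)cn2-c1ccc(C(C)C)cc1Br` gives 446 nM in an assay on isolated protein for binding affinity to corticotropin-releasing factor receptor 1 (Rattus norvegicus); a lower number here means a stronger inhibitor, a higher number a weaker inhibitor. Compound 2 `Cc1cc(Cl)nc2c1ccn2-c1ccc(C(C)C)cc1Br` gives 79 nM in this assay. Compound 3 `Cc1cc(Cl)c2c(C#N)cn(-c3ccc(C(C)C)cc3Br)c2n1` gives 722 nM in this assay.

Compound 1 and compound 2 share a core; the one difference is hydrogen in place of cyano on an aromatic carbon. That change produced a 5.6-fold lower number from compound 1 to compound 2 (0.75 log units; beyond the scatter). Compound 3 is built from the same atoms as compound 1, joined differently; the difference between the two cores is not broken down here. Among the three, compound 3 has the highest number, but its gap to compound 1 lies within the scatter, while its gap to compound 2 lies beyond it.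

Compound 4 `Cc1cc(Cl)c2ccn(-c3ccc(C(C)C)cc3Br)c2n1` has not yet been measured. It differs from compound 3 by hydrogen in place of cyano on an aromatic carbon, the same change as between compound 1 and compound 2, at a place described in the same words. For the measured compounds named here, for compound 4 the expected step is a 4.8-fold lower number from compound 3 to compound 4 (0.68 log units; beyond the scatter), resting on the single measured example, a 5.6-fold lower number from compound 1 to compound 2 (0.75 log units; beyond the scatter). The step has been measured on one core only; how large it is on the core of compound 3 is not known. The range is kept wide. Compound 4 is therefore estimated at 150 nM, likely between 50 nM and 450 nM.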

Compound 4, inhibition constant: 67 nM
Compound 4: the middle estimate sits 2.2-fold (0.35 log units) above what was measured, within the range that was stated.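

In this assay, putting hydrogen in place of the nitrile gave an 11-fold lower number from compound 3 to compound 4 (1.03 log units; beyond the scatter), so the change that lowered the number on the core of compound 1 also lowered it on the core of compound 3. Set side by side, the two steps agree, and the change carried over from one core to the other at a similar size: the same change on two cores in this assay, a 5.6-fold lower number (0.75 log units; beyond the scatter) from compound 1 to compound 2 and an 11-fold lower number (1.03 log units; beyond the scatter) from compound 3 to compound 4, 1.9-fold (0.28 log units) apart, within the scatter of two such steps. For the compounds shown here, this rests on only one pair of compounds for each core, so it supports carrying the change between these two cores but does not show that it would work on any other core, nor does it explain why losing the nitrile lowers the number.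

The compounds shown leave open whether a different group on this aromatic carbon, such as a methyl group, an amide or a carboxylic acid, would give a number closer to that of hydrogen or of the nitrile. They also leave open whether the step keeps its size when the chlorine is replaced by an amine.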